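Carboxy in Place of Hydroxy: Expecting Little Change

A few compounds are considered here, and "the series" means these few. Any claim that something is new, unique, unknown or untested is made for them only; others in the source may bear on it.

Measured compounds:
Compound 1, `Cc1ccc2nc(C(=O)Nc3c(F)cc(-c4cccc(F)c4)cc3F)c(C)c(O)c2c1`: 0.96%
Compound 2, `Cc1c(C(=O)Nc2c(F)cc(-c3cccc(F)c3)cc2F)nc2ccc(C(F)(F)F)cc2c1O`: 3.47%

In a functional assay on A-375 cells (Homo sapiens) for antiproliferative activity, read by MTT assay, with a stated time of 24 h, tested at 0.05 ug/mL (a lower number here means a weaker effect, a higher number a stronger effect of the compound at the concentration tested), compound 1 gives 0.96%. Among the measured compounds shown here, of the two numbers measured, it stands at the bottom, but its only neighbour, compound 2, gives 3.47%, and the step of a number 2.5 percentage points higher from compound 1 to compound 2 (within the scatter) is within the scatter, so the two compounds cannot be told apart on these numbers. Both sit close to no effect at the concentration tested.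

Compound 3, `Cc1ccc2nc(C(=O)Nc3c(F)cc(-c4cccc(F)c4)cc3F)c(C)c(C(=O)O)c2c1`, differs from compound 1 in one place: carboxy in place of hydroxy on an aromatic carbon. For the measured compounds named here, none of the measured steps touches this position. Going by the values given here, the single step known, the exchange of methyl for trifluoromethyl from compound 1 to compound 2, lay within the scatter, and it concerns a different part of the shared core. There is therefore no measured basis for expecting a step beyond the scatter in this assay from this change, in either direction.

For compound 3 the expected step is a number 1 percentage points higher from compound 1 to compound 3 (within the scatter). The estimate for compound 3 in this assay is 2%, with a range from -8% to 12%.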

Compound 3, a percentage reported as inhibition, at one concentration (the size of the read-out at that concentration, not a potency): 0.35%
For compound 3 the middle estimate is 1.7 percentage points above the measured one, within the range that was stated.
By their numbers in this assay, from the lowest: compounds 3, 1 and 2 (each within the scatter of the next).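

Among the compounds shown here, this is the first measured step at the aromatic carbon opposite the ring nitrogen: in this assay, carboxy in place of hydroxy gives a number 0.6 percentage points lower from compound 1 to compound 3 (within the scatter), so this change cannot be told apart from no change on these numbers. The step says little about how much this position matters, as compound 1 and compound 3 both sit close to no effect at the one concentration tested, and a read-out near that level leaves almost no room for a fall to show. No other measurement shown here bears on this result.

Whether any group at this position can lift the read-out clear of the scatter stays open, for example an amine or a methoxy group, both absent from the compounds shown. Also open, as far as these compounds go, is whether carboxy would behave the same way in the trifluoromethyl compound 2, or whether hydroxy and carboxy would separate in a test at a higher concentration, where the compounds might have an effect large enough to compare.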